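The source may hold more compounds than are shown below. What is called first, only, known or untested is meant among the compounds shown, and "the series" means these compounds.

Working notes on the series. Three measured analogues share one core: compound 1 `CNC(=O)/C=C/c1ccncc1-c1ccc2ccccc2c1`, compound 2 `CCOC(=O)/C=C/c1ccncc1-c1ccc2c(ccn2C)c1` and compound 3 `O=C(O)/C=C/c1ccncc1-c1ccc2cc[nH]c2c1`. In a functional assay on A549 cells (Homo sapiens) for inhibition, read by sulforhodamine B assay, with a stated time of 72 h (on this read-out higher numbers stand for weaker inhibition of growth and lower numbers for stronger inhibition of growth), compound 1 gives 6620 nM, the highest of the two numbers recorded in the set. Compound 2 gives 1720 nM in this assay, a gap from compound 1 that lies beyond the usual scatter. Compound 3 returns only a limit in this assay, > 10000 nM, which is the limit of > 10000 nM in this assay, at which 1 of the 3 values shown sits.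

The next compound is compound 4 `O=C(/C=C/c1ccncc1-c1ccc2ccccc2c1)NC1CC1`, not yet measured in this assay. Its change from compound 1 is cyclopropyl in place of methyl on an amide-type nitrogen. Among the measured compounds shown here, no measured pair in the set covers a change of this kind; the comparisons available differ from one another elsewhere, not on the amide-type nitrogen, so no measured step can be leaned on. The expectation is a step from compound 1 within or close to the usual scatter in this assay, with a slight lean toward stronger inhibition of growth.

Compound 4 is expected to give 4000 nM in this assay, with a range from 1500 nM to 12000 nM. The step this estimate means is a 1.7-fold lower number from compound 1 to compound 4 (0.22 log units; within the scatter).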

Compound 4, concentration for 50% growth inhibition: 5840 nM
Estimate against measurement, compound 4: 1.5-fold (0.16 log units) below; the measured number falls inside the stated range.
By their numbers in this assay, from the lowest: compound 2; then compounds 4 and 1 (each within the scatter of the next). At a limit, above all of these: compound 3.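

Among the compounds shown here, on the amide-type nitrogen, the step of a 1.1-fold lower number from compound 1 to compound 4 (0.05 log units; within the scatter) in this assay is the only measured reading of this position, and it shows that this assay does not separate methyl from cyclopropyl there. Going from one carbon to three and adding a three-membered ring at this place therefore leaves the number within the scatter, so compound 1 and compound 4 stand level, and the earlier compounds could not show this because none of them forms a one-place pair with another. No measured property on hand offers a reason for this step, and the limit recorded for compound 3 does not bear on it.

The two groups shown on this nitrogen are both small carbon groups, so it remains open whether a longer chain, a benzyl group or a chain ending in an amine would move the number beyond the scatter. From the compounds shown here alone, compound 2 and compound 3 differ from compound 1 and compound 4 in more than one place, so it also remains open how the amide itself compares with an ester or a carboxylic acid on the same core.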